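The compounds below may be only part of what the source reports. "The series", "measured", "known", "first", "only" and "open" are said of these compounds alone.

Measured compounds:
Compound 1 `COc1cc(CNC(=O)CCCC/C=C/C(C)C)ccc1OCc1nnc(Nc2ccc([N+](=O)[O-])cc2)o1`; in a functional assay on NCI-H460 cells (Homo sapiens) for inhibition, read by crystal violet staining, with a stated time of 72 h (a lower number here means a stronger inhibitor, a higher number a weaker inhibitor), compound 1 gives 5410 nM.
Compound 2 `COc1cc(CNC(=O)CCCC/C=C/C(C)C)ccc1OCc1nnc(Nc2ccccc2F)o1`; in this assay compound 2 gives 14400 nM.

Compound 2 stands highest of the two numbers, with compound 1 nearest to it, separated by the step of a 2.7-fold higher number from compound 1 to compound 2 (0.43 log units; beyond the scatter). Compound 3 `COc1cc(CNC(=O)CCCC/C=C/C(C)C)ccc1OCc1nnc(SCCc2c[nH]c3ccccc23)o1` differs from compound 2 by (2-(1H-indol-3-yl)ethyl)sulfanyl in place of (2-fluorophenyl)amino on an aromatic carbon. Within the data shown here, no measured step replaces the (2-fluorophenyl)amino group with a (2-(1H-indol-3-yl)ethyl)sulfanyl group, so only the one modest step at the same aromatic carbon, from a 4-nitrophenyl to a 2-fluorophenyl group, bears on it. A step of similar size, in either direction, or none beyond the scatter, is therefore expected in this assay. Compound 3 is estimated at 10000 nM, within 3000 nM to 30000 nM, an expected step of a 1.4-fold lower number from compound 2 to compound 3 (0.16 log units; within the scatter).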

Compound 3, half-maximal inhibitory concentration: 9890 nM
Estimate against measurement, compound 3: 1.0-fold (0.00 log units) above, and the stated range covers the measured number.
By their numbers in this assay, from the lowest: compounds 1, 3 and 2 (each within the scatter of the next, the first and the last beyond it).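

In this assay, the (2-(1H-indol-3-yl)ethyl)sulfanyl group on this aromatic carbon gives a 1.5-fold lower number from compound 2 to compound 3 (0.16 log units; within the scatter) and a 1.8-fold higher number from compound 1 to compound 3 (0.26 log units; within the scatter), so neither step leaves the scatter. This position therefore takes a group of 12 heavy atoms, joined through sulfur instead of nitrogen, with no difference beyond the scatter from either the (2-fluorophenyl)amino or the (4-nitrophenyl)amino compound. Nothing given here offers a reason for this. On these data alone, because the sulfur link and the indole ring enter together, their separate contributions stay open. Also open, as far as these compounds go, is whether a carboxylic acid or a morpholine on this carbon would give a step beyond the scatter.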